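From a substituted urea tail to a plain benzamide

The source may report more compounds than this note shows. Statements on the series, on what has been measured and on what is new or still open speak of the compounds shown alone.

Compound 2 `COc1cc(-c2nn(-c3cccc(NC(=O)Nc4ccc(Cl)c(C(F)(F)F)c4)c3)cc2-c2ccncc2)ccc1Cl` gives 870 nM in a functional assay on RPMI-8226 cells (Homo sapiens) for inhibition, read by sulforhodamine B assay, with a stated time of 48 h (a higher number here means a weaker inhibitor, a lower number a stronger inhibitor), the lower of the two numbers in hand, though only within the scatter of compound 1 `COc1cc(-c2nn(-c3cccc(NC(=O)c4cccc(C(F)(F)F)c4)c3)cc2-c2ccncc2)ccc1Cl`, which gives 1570 nM. Going by the values given here, the sole measured step, a 1.8-fold lower number from compound 1 to compound 2 (0.26 log units; within the scatter), shows that swapping the amide tail for the urea tail barely moved the number. Compound 3 `COc1cc(-c2nn(-c3cccc(NC(=O)c4ccccc4)c3)cc2-c2ccncc2)ccc1Cl` carries the change (phenyl in place of (4-chloro-3-(trifluoromethyl)phenyl)amino on a carbonyl carbon). Among the compounds with values here, no measured step covers removal of the chlorine and trifluoromethyl groups, so compound 3 is expected to show a modest rise, a 3.4-fold higher number from compound 2 to compound 3 (0.54 log units; beyond the scatter), with wide uncertainty. Compound 3 is estimated at 3000 nM, between 1200 nM and 8000 nM.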

Compound 3, half-maximal inhibitory concentration: 850 nM
Estimate against measurement, compound 3: 3.5-fold (0.55 log units) above; measured number below the stated range.
By their numbers in this assay, from the lowest: compounds 3, 2 and 1 (each within the scatter of the next).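

In this assay, the larger tail and a bare ring on the carbonyl carbon cannot be told apart: phenyl in place of (4-chloro-3-(trifluoromethyl)phenyl)amino gives a 1.0-fold lower number from compound 2 to compound 3 (0.01 log units; within the scatter). Hydrogen in place of trifluoromethyl on an aromatic carbon gives a 1.8-fold lower number from compound 1 to compound 3 (0.27 log units; within the scatter), so neither the trifluoromethyl group nor the urea tail is needed to reach numbers of this size. No supporting measurement explains why these tails read alike.

On these data alone, whether a small group such as an amine or a carboxylic acid in place of the phenyl on the carbonyl carbon would move the number beyond the scatter remains open.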